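Sulfonyl aryl swap in a quinoline sulfone series

The source may hold more compounds than are shown below. What is called first, only, known or untested is meant among the compounds shown, and "the series" means these compounds.

Compound 1 `O=S(=O)(c1ccc(F)c(Cl)c1)c1cnc2cc(F)ccc2c1-c1ccc(Cl)cc1` is the reference point of this set. Among the measured compounds shown here, in an ADME assay on microsomes from liver (Homo sapiens) for metabolic stability, tested at 2.5 uM (on this read-out lower numbers stand for slow clearance and higher numbers for fast clearance), compound 1 gives 0.39 mL/min, the lowest of the two numbers measured so far. For the measured compounds named here, its only measured neighbour is compound 2 `O=S(=O)(c1ccc(F)c(Cl)c1)c1cnc2cc(F)ccc2c1-c1ccccc1F`, which in this assay gives 1.07 mL/min; the step of a 2.7-fold higher number from compound 1 to compound 2 (0.44 log units; beyond the scatter) concerns the aryl on the aromatic carbon of the shared core, not the sulfonyl side.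

Compound 3 `Cc1ccc(S(=O)(=O)c2cnc3cc(F)ccc3c2-c2ccc(Cl)cc2)cc1C` keeps the core of compound 1 and changes the group on the sulfonyl sulfur: 3,4-dimethylphenyl in place of 3-chloro-4-fluorophenyl on a sulfonyl sulfur. Going by the values given here, no measured step touches this position, so the one step recorded, from compound 1 to compound 2, bears on it only as a gauge of how much a single aryl exchange has moved the number. Against that background a modest rise is expected rather than a flat result, with the estimated step of a 2.1-fold higher number from compound 1 to compound 3 (0.31 log units; beyond the scatter) in this assay. For compound 3 in this assay the estimate is 0.8 mL/min, with a range from 0.35 mL/min to 1.8 mL/min.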

Compound 3, intrinsic clearance in a liver preparation (reported as CLH), per the amount of preparation that the assay uses: 7.88 mL/min
Beside the measured number, compound 3's estimate is 9.9-fold (0.99 log units) below it; measured number above the stated range.
By their numbers in this assay, from the lowest: compound 1; then compound 2; then compound 3.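

In this assay, the group on the sulfonyl sulfur emerges as a sensitive place in this series: the exchange gives a 20-fold higher number from compound 1 to compound 3 (1.31 log units; beyond the scatter), a larger step than the aryl exchange on the aromatic carbon of the shared core (a 2.7-fold higher number from compound 1 to compound 2 (0.44 log units; beyond the scatter)). The leaving and entering groups share the same kind of ring and the same listed counts of heavy atoms, donors and acceptors, so this large step comes with a change in which carbon replaces the chlorine and fluorine of 3-chloro-4-fluorophenyl, while the ring type stays the same. No measurement at hand accounts for the rise, so the step stands as an observation on a single pair.

Still open, going by these compounds, is whether the two methyl groups of 3,4-dimethylphenyl contribute together or whether one alone carries the step, which a 3-methylphenyl or a 4-methylphenyl on the sulfonyl sulfur would help separate. Also open, on these data alone, are how a methoxy group or a nitrile on that ring would read in this assay, and whether the same sulfonyl exchange would give a step of similar size with the 2-fluorophenyl of compound 2 in place.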